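Moving the Halogen on the Pendant Phenyl: Cytotoxicity Outlook

A few compounds are considered here, and "the series" means these few. Any claim that something is new, unique, unknown or untested is made for them only; others in the source may bear on it.

Compound 1 `O=c1[nH]cc(S(=O)(=O)Nc2cccc(-c3cn(-c4ccccc4)nn3)c2)c(=O)[nH]1` gives > 100000 nM in an ADME assay on L02 cells (Homo sapiens) for cytotoxicity, read by MTT assay, with a stated time of 24 h; on this read-out lower numbers stand for higher toxicity in this test and higher numbers for lower toxicity in this test. Compound 2 `Cc1cccc(-n2cc(-c3cccc(NS(=O)(=O)c4c[nH]c(=O)[nH]c4=O)c3)nn2)c1` gives 28300 nM in this assay. Compound 3 `O=c1[nH]cc(S(=O)(=O)Nc2cccc(-c3cn(-c4cccc(F)c4)nn3)c2)c(=O)[nH]1` is reported as "not toxic" (no number reported) in this assay.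

The number for compound 1 is a limit of this assay, not a measured value, and it is the limit described as the limit of > 100000 nM in this assay, at which 1 of the 3 values shown sits. Going by the values given here, only one pair of measured compounds differs in a single place: an at least 3.5-fold lower number from compound 1 to compound 2 (0.54 log units; beyond the scatter), the change being methyl in place of hydrogen on an aromatic carbon. Compound 3 carries no number at all; it stands on the record only as not toxic, alongside compound 1 at the limit.

Compound 4 `O=c1[nH]cc(S(=O)(=O)Nc2cccc(-c3cn(-c4ccccc4Cl)nn3)c2)c(=O)[nH]1` has not been measured. It differs from compound 3 by 2-chlorophenyl in place of 3-fluorophenyl on an aromatic nitrogen. Among the compounds with values here, no measured step involves a halogen or a change of its position, so the one known step, which concerns a methyl group, does not bear on this change. Compound 3 and compound 1, both without a toxic number, are the nearest points of reference.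

On that basis compound 4 is expected to show little cytotoxicity in this assay, with an estimate of 100000 nM and a range from 30000 nM to 300000 nM, and a real chance that only a limit is reported.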

Compound 4, half-maximal cytotoxic concentration: 11500 nM
The estimate for compound 4 lay 8.7-fold (0.94 log units) above the measured number, outside the stated range (below it).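

A halogen on the pendant phenyl does not keep the shared core free of a measurable toxic concentration in this assay: adding a chloro group to the bare pendant phenyl gives an at least 8.6-fold lower number from compound 1 to compound 4 (0.93 log units; beyond the scatter), and 2-chlorophenyl in place of 3-methylphenyl gives a 2.5-fold lower number from compound 2 to compound 4 (0.39 log units; beyond the scatter). Going by these compounds alone, compound 1 stands at a limit and not at a number, which leaves the size of the first of these steps open on one side: the limit of > 100000 nM in this assay, at which 1 of the 4 values shown sits. Compound 3, with 3-fluorophenyl, goes against any rule that a halogen on this ring lowers the number, but it carries no number of its own, and no step between it and the chlorinated compound can be read.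

The compounds shown do not separate the kind of halogen from its place on the ring, a question that 3-chlorophenyl and 2-fluorophenyl would bear on, and 2-methylphenyl would do the same for the methyl group. They also leave open how an amine or a carboxylic acid on the pendant phenyl would read in this assay.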